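The source may report more compounds than this note shows. Statements on the series, on what has been measured and on what is new or still open speak of the compounds shown alone.

Measured in a functional assay on A549 cells (Homo sapiens) for inhibition, read by sulforhodamine B assay, with a stated time of 72 h; on this read-out higher numbers stand for weaker inhibition of growth and lower numbers for stronger inhibition of growth:
- compound 1 `CNC(=O)/C=C/c1ccncc1-c1ccc2ccccc2c1`: 6620 nM
- compound 2 `CCOC(=O)/C=C/c1ccncc1-c1ccc2[nH]ccc2c1`: 7440 nM
- compound 3 `CCOC(=O)/C=C/c1ccncc1-c1ccc2cc[nH]c2c1`: 5740 nM

In this assay, compound 1 at 6620 nM lies within the scatter of both compound 2 and compound 3, so the three values do not separate these compounds. For the measured compounds named here, compound 2 and compound 3 each differ from compound 1 in more than one place, and no measured pair isolates a single change.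

Compound 4 `O=C(/C=C/c1ccncc1-c1ccc2ccccc2c1)N1CCOCC1` keeps the core of compound 1 and carries morpholin-4-yl in place of methylamino on a carbonyl carbon. Going by the values given here, the data contain no measured example of this change, so its size cannot be read from them directly. Among the compounds with values here, the only guide is the narrow spread of the three values, and no effect beyond the scatter is expected in this assay, in either direction. The estimated step of a 1.1-fold lower number from compound 1 to compound 4 (0.04 log units; within the scatter) is accordingly expected to stay small, though with wide uncertainty. Compound 4 is estimated at 6000 nM, with an expected range from 2500 nM to 14000 nM.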

Compound 4, concentration for 50% growth inhibition: 8410 nM
Estimate against measurement, compound 4: 1.4-fold (0.15 log units) below, within the range that was stated.
By their numbers in this assay, from the lowest: compounds 3, 1, 2 and 4 (each within the scatter of the next).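

In this assay, for the compounds shown here, the first step that changes a single place gives a 1.3-fold higher number from compound 1 to compound 4 (0.10 log units; within the scatter), with morpholin-4-yl in place of methylamino on a carbonyl carbon. This shows that a larger group, with a six-membered non-aromatic ring and no hydrogen-bond donor, can stand at this position without moving the number beyond the scatter, so the amide hydrogen of compound 1 is not needed to keep growth inhibition at this level in this assay. No supporting information bears on why the two amides read alike.

From the compounds shown here alone, it remains open whether a carboxylic acid, a primary amide or a longer chain such as hexylamino on this carbonyl carbon would shift the number beyond the scatter. Going by these compounds, it also remains open whether morpholin-4-yl would behave the same way on the cores of compound 2 and compound 3.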